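This account rests on a few compounds, and the source may have more. Where it says the series, first, only, none or still open, it means among the compounds named here.

Compound 1 `c1ccc(-c2cnccn2)c(OCC2=NCCN2)c1` gives 631 nM in a functional assay for activation of Alpha-1B adrenergic receptor (Homo sapiens), read by calcium flux; on this read-out lower numbers stand for an effect already at smaller amounts and higher numbers for an effect only at larger amounts of compound. Compound 2 `c1ccc(-c2cc[nH]n2)c(OCC2=NCCN2)c1` gives 79.4 nM in this assay. Compound 3 `c1ccc(-c2ncc[nH]2)c(OCC2=NCCN2)c1` gives < 100000 nM in this assay, which is a limit of the assay and not a number (the limit of < 100000 nM in this assay, at which 1 of the 3 values shown sits).

Compound 3 thus stands only as a limit in this assay, with no number of its own. Compound 4 `Cc1cnsc1-c1ccccc1OCC1=NCCN1` follows from compound 3 by 4-methyl-1,2-thiazol-5-yl in place of 1H-imidazol-2-yl on an aromatic carbon. The measured steps that touch the same ring are a step that the limit leaves unreadable from compound 1 to compound 3 and a step that the limit leaves unreadable from compound 2 to compound 3, both left unreadable by the limit; no readable step therefore bears on the change to compound 4. Compound 1 and compound 2 both gave numbers in this assay. Compound 4 is expected to give a number as well, the step that the limit leaves unreadable from compound 3 to compound 4 being expected to stay unreadable against the limit. Compound 4 is estimated at 300 nM in this assay, with a range from 30 nM to 3000 nM.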

Compound 4, half-maximal effective concentration: < 100000 nM
Compound 4 was reported as a limit; the forecaster's own chance of this, stated with the estimate: 10%; the middle value lies beyond the limit too.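

Compound 4 stands only as a limit in this assay, so no step from compound 1, compound 2 or compound 3 to compound 4 can be read: the limit of < 100000 nM in this assay, at which 2 of the 4 values shown sit.

The compounds shown leave open how far the 1H-imidazol-2-yl and 4-methyl-1,2-thiazol-5-yl compounds actually lie from compound 1 and compound 2.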